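Azole exchange on the shared core: compound 3 to compound 4

The source may hold more compounds than are shown below. What is called first, only, known or untested is meant among the compounds shown, and "the series" means these compounds.

Compound 3 `O=C(O)c1cc(-c2cc[nH]n2)ccc1O` stands only at a limit in a functional assay on the whole organism for inhibition, with Rattus norvegicus as the target, read by paw edema; on this read-out higher numbers stand for an effect only at larger amounts of compound and lower numbers for an effect already at smaller amounts: compound 3 gives > 250 mg/kg. Compound 1 `O=C(O)c1cc(-c2cncs2)ccc1O` likewise gives only a limit; in this assay compound 1 gives > 200 mg/kg. Among the compounds with values here, compound 2 `O=C(O)c1cc(-c2cocn2)ccc1O` is the one member with a number: in this assay compound 2 gives 110 mg/kg. The steps among them read an at least 1.8-fold lower number from compound 1 to compound 2 (0.25 log units; that floor lies within the scatter), an at least 2.2-fold higher number from compound 2 to compound 3 (0.35 log units; beyond the scatter) and a step that the two limits leave unreadable from compound 1 to compound 3.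

Compound 4 `O=C(O)c1cc(-n2nccn2)ccc1O` differs from compound 3 in one place: 2H-1,2,3-triazol-2-yl in place of 1H-pyrazol-3-yl on an aromatic carbon. The measured steps that bear on it are those ending at compound 3, and both rest on the limit (the limit of > 250 mg/kg in this assay, at which 1 of the 3 values shown sits); the step from compound 2 yields only a floor, and the step from compound 1 is unreadable because both ends are limits the limit of > 200 mg/kg in this assay, at which 1 of the 3 values shown sits (the limit of > 250 mg/kg in this assay, at which 1 of the 3 values shown sits). With the starting point itself unquantified, no size or direction of step beyond the scatter can be derived in this assay. Compound 4 is expected to give 200 mg/kg, estimated within 90 mg/kg to 450 mg/kg. The step this estimate means is an at least 1.2-fold lower number from compound 3 to compound 4 (0.09 log units; that floor lies within the scatter), an expectation and not a measurement.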

Compound 4, dose for half-maximal effect: 150 mg/kg
Compound 4: middle estimate off by 1.3-fold (0.12 log units), on the high side; low and high end bracket the measured number.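

The exchange of 1,3-oxazol-4-yl for 2H-1,2,3-triazol-2-yl gives a 1.4-fold higher number from compound 2 to compound 4 (0.13 log units; within the scatter), so at this position the two groups cannot be told apart in this assay. Replacing 1H-pyrazol-3-yl, with 1 hydrogen-bond donor, by the triazolyl group, with 0, gives an at least 1.6-fold lower number from compound 3 to compound 4 (0.22 log units; that floor lies within the scatter), and replacing 1,3-thiazol-5-yl gives an at least 1.3-fold lower number from compound 1 to compound 4 (0.12 log units; that floor lies within the scatter), so neither floor by itself shows a step beyond the scatter. The second floor rests on a limit of compound 1: the limit of > 200 mg/kg in this assay, at which 1 of the 4 values shown sits.

From the compounds shown here alone, the true size of the step from 1H-pyrazol-3-yl stays open, because compound 3 also stands at a limit: the limit of > 250 mg/kg in this assay, at which 1 of the 4 values shown sits. Whether an amine or a longer chain in place of the azole would move the number beyond the scatter also stays open.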